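Notes on a sulfonylmethyl series and one untested analogue

The source may report more compounds than this note shows. Statements on the series, on what has been measured and on what is new or still open speak of the compounds shown alone.

Compound 2 `O=S(=O)(CC1=NCCS1)C1C(c2ccccc2)=NN(c2ccccc2)C1c1ccccc1` is reported in a functional assay, read by Griess assay, with a stated time of 150 min, tested at 100 ug/mL (on this read-out lower numbers stand for a weaker effect and higher numbers for a stronger effect at the one concentration tested), as "not active" (no number reported), and compound 1 `O=S(=O)(CC1=NCCS1)C1=NNCC1c1ccccc1` likewise gives "not active" (no number reported). Among the compounds with values here, compound 3 `O=S(=O)(CC1=NCCO1)c1c(-c2ccccc2)noc1-c1ccccc1` is the only member with a reported number, giving 62.1% in this assay. Within the data shown here, compound 2 thus stands among the members for which no number is reported, and no step between two measured compounds is available for comparison. Compound 4 `O=S(=O)(CC1=NCCO1)C1C(c2ccccc2)=NN(c2ccccc2)C1c1ccccc1` differs from compound 2 in one place: a group of 5 heavy atoms (3 carbon, 1 nitrogen, 1 oxygen; one five-membered non-aromatic ring with 2 hetero atoms) in place of a group of 5 heavy atoms (3 carbon, 1 nitrogen, 1 sulfur; one five-membered non-aromatic ring with 2 hetero atoms), on a saturated chain carbon bound to a sulfonyl sulfur. Among the measured compounds shown here, no measured pair shows what this change does to the read-out; a step of modest size toward a stronger effect is conceivable, but none beyond the usual scatter is the more cautious expectation. Compound 4 is expected to give 20% in this assay, with a range from 0% to 50%.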

Compound 4, a percentage reported as activity, at one concentration (the size of the read-out at that concentration, not a potency): 57.9%
The estimate for compound 4 lay 37.9 percentage points below the measured number; measured number outside the range, above it.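

Within the data shown here, compound 2 has no number in this assay and compound 4 has one, so no step between them can be read. The compounds shown leave open what the exchange of ring sulfur for oxygen does to the read-out. No measured evidence bears on this result.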